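The source may report more compounds than this note shows. Statements on the series, on what has been measured and on what is new or still open speak of the compounds shown alone.

Measured compounds in a physicochemical assay for solubility, read by LC-MS, in phosphate buffer, with a stated time of 24 h, at pH 7.4; a lower number here means a less soluble compound, a higher number a more soluble compound:
compound 1 `Cn1cc(-c2cnc(NCc3c(F)ccc4c3CCO4)c3cn[nH]c(=O)c23)cn1` gives 1000 nM
compound 2 `CN(C)Cc1ccc(C(=O)Nc2cnc(NCc3c(F)ccc4c3CCO4)n3cnnc23)cc1` gives 520000 nM
compound 3 `O=C(Nc1cnc(NCc2c(F)ccc3c2CCO3)n2cnnc12)c1cccnc1` gives 12000 nM

Compound 1 stands lowest of the three numbers in this assay. Its nearest neighbour is compound 3, whose value sits well beyond the scatter above it, and compound 2 lies furthest above it. Among the compounds with values here, the one step measured within one shared core, a 43-fold lower number from compound 2 to compound 3 (1.64 log units; beyond the scatter), concerns a different core and a different kind of exchange on a carbonyl carbon, so it does not speak directly to what follows.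

Compound 4 `CNC(=O)c1cc(-c2cnc(NCc3c(F)ccc4c3CCO4)c3cn[nH]c(=O)c23)n(C)n1` is the unmeasured compound. It differs from compound 1 in one place: 1-methyl-3-(methylcarbamoyl)-1H-pyrazol-5-yl in place of 1-methyl-1H-pyrazol-4-yl on an aromatic carbon. Within the data shown here, no measured pair shows this particular exchange, so the expectation rests only on the group that enters, which carries one hydrogen-bond donor and three acceptors where the leaving group carried none and two, and on the low standing of compound 1 at 1000 nM. On that basis a modest rise in this assay is expected, one that may or may not clear the scatter, and the expected step is a 3.0-fold higher number from compound 1 to compound 4 (0.48 log units; beyond the scatter). The estimated value for compound 4 in this assay is 3000 nM, with a range from 800 nM to 12000 nM.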

Compound 4, solubility: 7000 nM
Compound 4: the middle estimate sits 2.3-fold (0.37 log units) below what was measured; the range from low to high includes it.
By their numbers in this assay, from the lowest: compound 1; then compounds 4 and 3 (each within the scatter of the next); then compound 2.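

In this assay, the first step read on the core of compound 1 is a 7.0-fold higher number from compound 1 to compound 4 (0.85 log units; beyond the scatter), for 1-methyl-3-(methylcarbamoyl)-1H-pyrazol-5-yl in place of 1-methyl-1H-pyrazol-4-yl. Within the data shown here, until now, the only step on record belonged to a different core and a different kind of exchange, so this is the first reading at this aromatic carbon, para to a large group. It shows that on this core a larger pyrazole, carrying a methylcarbamoyl group and a hydrogen-bond donor that the leaving group lacks, goes with a higher number, and no measurement on hand gives a reason for the rise.

The exchange alters two things at once, the added methylcarbamoyl group and the attachment of the pyrazole through its 5-yl rather than its 4-yl carbon, and the compounds shown do not separate these two changes. They also leave open how the number would respond if a carboxylic acid stood in place of the methylcarbamoyl group, or if a longer chain replaced the methyl on its amide nitrogen.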